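Swapping a Short Chain for an Aminomethylphenyl Group

The compounds below may be only part of what the source reports. "The series", "measured", "known", "first", "only" and "open" are said of these compounds alone.

Of the compounds shown here, two have so far been tested in an assay on isolated protein for inhibition of Rho-associated protein kinase 1 (Homo sapiens), read by scintillation counting, radiometric assay and 33P incorporation, with a stated time of 40 min, in the presence of a further agent that is not named here; a higher number here means a weaker inhibitor, a lower number a stronger inhibitor. Compound 1 `CN(C)c1ccc(C(=O)Nc2cccc(NC(=O)COc3ccc4c(c3)OCCO4)c2)cc1` gives only a limit in this assay, > 10000 nM, so no number is known for it. Within the data shown here, compound 2 `CCCC(=O)Nc1cccc(NC(=O)COc2ccc3c(=O)ccoc3c2)c1` gives 1430 nM in this assay, the single measured number in the set. The other entry, that of compound 1, stands apart from it only as a limit (the limit of > 10000 nM in this assay, at which 1 of the 2 values shown sits). Compound 3 `NCc1ccc(C(=O)Nc2cccc(NC(=O)COc3ccc4c(=O)ccoc4c3)c2)cc1` has not yet been measured. It differs from compound 2 in one place: 4-(aminomethyl)phenyl in place of propyl on a carbonyl carbon. Among the measured compounds shown here, no measured pair shares this change, so any expectation rests on the structural change alone. The step is expected to be a 3.6-fold lower number from compound 2 to compound 3 (0.55 log units; beyond the scatter) in this assay, toward stronger inhibition. Compound 3 is therefore estimated to give about 400 nM in this assay, with a range from 80 nM to 2500 nM.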

Compound 3, half-maximal inhibitory concentration: 532 nM
For compound 3 the middle estimate is 1.3-fold (0.12 log units) below the measured one; the range from low to high includes it.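

Among these compounds, replacing propyl with 4-(aminomethyl)phenyl on a carbonyl carbon gives a 2.7-fold lower number from compound 2 to compound 3 (0.43 log units; beyond the scatter) in this assay, the first step that can be read as a number. It shows that this place accepts a larger group, one carrying an aromatic ring and an aminomethyl group, and that inhibition is stronger with it, though the gain remains modest. Nothing measured here explains why this step occurs.

The compounds shown leave open whether the ring or the aminomethyl group accounts for the step, since both enter together. A plain phenyl group at the same place would help to separate the two, while a longer chain such as hexyl would test whether added size without a ring gives a similar step.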